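From a Fluorophenyl Ether to a Trichlorophenyl Ether

The compounds below may be only part of what the source reports. "The series", "measured", "known", "first", "only" and "open" are said of these compounds alone.

Three compounds share one core and differ only in the aryl group carried on an oxygen on a saturated carbon. Compound 1 `NC1=NC2(CCOCC2)N(OCCCOc2cccc(Cl)c2)C(N)=N1` carries a 3-chlorophenyl there, and in an assay on isolated protein for inhibition of Dihydrofolate reductase (Homo sapiens), read by spectrophotometry, using NADPH, with stated times of 5 s and 6 min, tested at 5 uM (on this read-out higher numbers stand for a stronger effect at the one concentration tested and lower numbers for a weaker effect), compound 1 gives 83.2%. Compound 2 `NC1=NC2(CCOCC2)N(OCCCOc2ccc(F)cc2)C(N)=N1` carries a 4-fluorophenyl instead. In this assay compound 2 reaches > 90%, which is a limit of the measurement rather than a number. Going by the values given here, the single measured step, a number at least 6.8 percentage points higher from compound 1 to compound 2 (that floor lies within the scatter), therefore sets only a floor, and that floor lies within the usual scatter; compound 2 stands at the limit of > 90% in this assay, at which 1 of the 2 values shown sits. Compound 3 `NC1=NC2(CCOCC2)N(OCCCOc2cc(Cl)c(Cl)cc2Cl)C(N)=N1` is not yet measured. 2,4,5-trichlorophenyl in place of 4-fluorophenyl on an oxygen on a saturated carbon This exchange of one ring for another on the same oxygen resembles the measured step only loosely, since that step swapped a chlorine-bearing ring for a fluorine-bearing one and the read-out rose or stayed level. With compound 2 already at the limit, little room remains for a further rise. For compound 3 the expected step is a step that the limit leaves unreadable from compound 2 to compound 3, nothing beyond the scatter. Compound 3 is estimated at 91%, with a range from 78% to 100%, and the measurement may again report only the limit.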

Compound 3, a percentage reported as inhibition, at one concentration (the size of the read-out at that concentration, not a potency): > 90%
Compound 3 ended at the assay's limit (the forecaster's own chance of this, stated with the estimate: 55%); the middle value is on the limit's open side.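

Compound 3 shows that this place, on an oxygen on a saturated carbon, can carry a 2,4,5-trichlorophenyl, with its three chlorine atoms, and the read-out in this assay still reaches the limit. Going by these compounds alone, its one readable step is a number at least 6.8 percentage points higher from compound 1 to compound 3 (that floor lies within the scatter) and so does not establish a real rise over the 3-chlorophenyl of compound 1. The step between the 4-fluorophenyl and the 2,4,5-trichlorophenyl cannot be read, and these two rings cannot be put in any order, since both compounds sit at the same ceiling: the limit of > 90% in this assay, at which 2 of the 3 values shown sit.

Going by these compounds, how far the true effects of compound 2 and compound 3 lie past that limit stays open, and only values that fall below it could separate these rings. Also open, on these data alone, is how the read-out would respond to an amine or a carboxylic acid on the ring, or to a longer chain joining the oxygen to the shared core.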